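Replacing 4-hydroxy-3,5-dimethoxyphenyl with 4-bromophenyl

The source may report more compounds than this note shows. Statements on the series, on what has been measured and on what is new or still open speak of the compounds shown alone.

In a functional assay on PC-3 cells (Homo sapiens) for cytotoxicity, read by MTT assay, with a stated time of 72 h (a lower number here means a stronger inhibitor, a higher number a weaker inhibitor), three compounds sharing one core have been measured. Compound 1 (`N#Cc1ccc(/C=C/C(=O)Nc2cc3c(Nc4ccc(F)c(Cl)c4)ncnc3cc2O[C@H]2CCOC2)cc1`) gives 36600 nM, compound 2 (`O=C(/C=C/c1ccccc1[N+](=O)[O-])Nc1cc2c(Nc3ccc(F)c(Cl)c3)ncnc2cc1O[C@H]1CCOC1`) gives 7760 nM, and compound 3 (`COc1cc(/C=C/C(=O)Nc2cc3c(Nc4ccc(F)c(Cl)c4)ncnc3cc2O[C@H]2CCOC2)cc(OC)c1O`) gives 26500 nM. Compound 3 therefore holds the second highest of the three numbers, within the scatter of compound 1 and beyond the scatter of compound 2.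

Compound 4 (`O=C(/C=C/c1ccc(Br)cc1)Nc1cc2c(Nc3ccc(F)c(Cl)c3)ncnc2cc1O[C@H]1CCOC1`) carries 4-bromophenyl in place of 4-hydroxy-3,5-dimethoxyphenyl on a double-bonded chain carbon bound to a double-bonded chain carbon. Within the data shown here, the closest precedent is a 1.4-fold lower number from compound 1 to compound 3 (0.14 log units; within the scatter), which exchanges 4-cyanophenyl, the measured group most like 4-bromophenyl, for the group that compound 4 loses. Among the measured compounds shown here, the larger steps, a 4.7-fold lower number from compound 1 to compound 2 (0.67 log units; beyond the scatter) and a 3.4-fold higher number from compound 2 to compound 3 (0.53 log units; beyond the scatter), both involve 2-nitrophenyl, which has no close counterpart in compound 4. No step beyond the scatter is therefore expected in this assay, and the estimated step is a 1.3-fold lower number from compound 3 to compound 4 (0.12 log units; within the scatter). Compound 4 is expected at 20000 nM, with an estimated range of 7000 nM to 50000 nM.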

Compound 4, half-maximal inhibitory concentration: 28200 nM
Compound 4: middle estimate off by 1.4-fold (0.15 log units), on the low side, within the range that was stated.
By their numbers in this assay, from the lowest: compound 2; then compounds 3, 4 and 1 (each within the scatter of the next).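

In this assay the change to 4-bromophenyl gives a 1.1-fold higher number from compound 3 to compound 4 (0.03 log units; within the scatter) and so stays within the scatter, even though the group that leaves counts hydrogen-bond donors and acceptors and the group that enters counts none. Bromo in place of cyano on an aromatic carbon gives a 1.3-fold lower number from compound 1 to compound 4 (0.11 log units; within the scatter) and also stays within the scatter, while a 3.6-fold higher number from compound 2 to compound 4 (0.56 log units; beyond the scatter) lies beyond it, so that among these four compounds only compound 2, with its 2-nitrophenyl group, stands apart from the others. No measured evidence is available to explain this separation.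

The compounds shown leave open whether the lower number of compound 2 would persist with 2-bromophenyl or 4-nitrophenyl on the same carbon. They also leave open how an aminophenyl or carboxyphenyl group would compare there.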